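Methyl in place of ring hydrogen: expected shift

The source may report more compounds than this note shows. Statements on the series, on what has been measured and on what is new or still open speak of the compounds shown alone.

Compound 2 `Clc1ccc(Cn2cc(C3CC(c4ccncc4)=NO3)c3ccccc32)cc1` gives 25700 nM in a functional assay on PC-3 cells (Homo sapiens) for inhibition, read by MTT assay, with a stated time of 48 h; a higher number here means a weaker inhibitor, a lower number a stronger inhibitor. Compound 1 `Cc1[nH]c2ccccc2c1C1CC(c2ccncc2)=NO1` gives 21200 nM in this assay. Of the two numbers shown, that of compound 2 is the upper one, but the gap to compound 1 lies within the scatter. Compound 3 `Cc1c(C2CC(c3ccncc3)=NO2)c2ccccc2n1Cc1ccc(Cl)cc1` differs from compound 2 by methyl in place of hydrogen on an aromatic carbon. Among the compounds with values here, no measured pair shows a step of this kind, so no direction can be read from the data. The step of a 1.2-fold lower number from compound 2 to compound 3 (0.07 log units; within the scatter) is expected to stay within the scatter. Compound 3 is estimated at 22000 nM, with a range from 8000 nM to 60000 nM.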

Compound 3, half-maximal inhibitory concentration: 11200 nM
Compound 3: the middle estimate sits 2.0-fold (0.29 log units) above what was measured; the range from low to high includes it.
By their numbers in this assay, from the lowest: compounds 3, 1 and 2 (each within the scatter of the next, the first and the last beyond it).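

In this assay methyl on this aromatic carbon, next to the ring nitrogen, gives a 2.3-fold lower number from compound 2 to compound 3 (0.36 log units; beyond the scatter), the first step of this kind in the series and one that lies beyond the scatter. With that methyl present, 4-chlorobenzyl in place of hydrogen on the aromatic nitrogen gives a 1.9-fold lower number from compound 1 to compound 3 (0.28 log units; within the scatter), which stays within the scatter. Nothing available accounts for the methyl step. From the compounds shown here alone, whether ethyl or an aminomethyl group on this carbon would follow methyl remains open. So does whether the methyl step holds with a carboxylic acid chain in place of 4-chlorobenzyl.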